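The source may report more compounds than this note shows. Statements on the series, on what has been measured and on what is new or still open speak of the compounds shown alone.

In a functional assay on PC-3 cells (Homo sapiens) for cytotoxicity (a higher number here means a weaker inhibitor, a lower number a stronger inhibitor), compound 1 `COc1ccc(Cn2cc(/C=N\NC(=O)c3c[nH]c4ccccc34)c3ccccc32)cc1` gives 14600 nM, and its fluoro analogue, compound 2 `COc1ccc(Cn2cc(/C=N\NC(=O)c3c[nH]c4ccccc34)c3ccc(F)cc32)cc1`, gives 18400 nM. That change, a 1.3-fold higher number from compound 1 to compound 2 (0.10 log units; within the scatter), lies within the scatter, so compound 1 cannot be separated from compound 2 on these numbers. Compound 3 `O=C(N/N=C\c1cn(Cc2ccc(Cl)cc2)c2ccccc12)c1c[nH]c2ccccc12` keeps the core of compound 1 but carries 4-chlorobenzyl in place of 4-methoxybenzyl, which is chloro in place of methoxy on an aromatic carbon. For the measured compounds named here, no measured step makes this exact change. Going by the values given here, the fluoro step from compound 1 to compound 2 is the only guide, and it is a different change that shifted the number by no more than the scatter. No clear move in either direction is therefore expected, and the estimated change is a 1.1-fold lower number from compound 1 to compound 3 (0.05 log units; within the scatter). For compound 3 the estimate is 13000 nM, with an expected range from 5000 nM to 32000 nM.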

Compound 3, half-maximal inhibitory concentration: 16200 nM
Beside the measured number, compound 3's estimate is 1.2-fold (0.10 log units) below it, and the stated range covers the measured number.
By their numbers in this assay, from the lowest: compounds 1, 3 and 2 (each within the scatter of the next).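

For the compounds shown here, the fluoro step in compound 2 lies elsewhere in the molecule, so this is the first view of the para position on the benzyl ring, the position para to a large group. In this assay, chloro in place of methoxy gives a 1.1-fold higher number from compound 1 to compound 3 (0.05 log units; within the scatter), so these two groups cannot be told apart here, even though the change removes the methoxy oxygen, a hydrogen-bond acceptor, and swaps two heavy atoms for one. Nothing available explains this result.

From the compounds shown here alone, only these two groups appear at this position, so it remains open whether an amine, a carboxylic acid or a longer chain such as butoxy there would shift the number beyond the scatter. Going by these compounds, it is also open whether removing the substituent altogether, leaving a plain benzyl, would matter.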